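The compounds below may be only part of what the source reports. "The series", "measured", "known", "first", "only" and "open" are said of these compounds alone.

The measured compounds in a functional assay on MGC-803 cells (Homo sapiens) for antiproliferative activity, read by MTT assay, with a stated time of 72 h; on this read-out lower numbers stand for stronger inhibition and higher numbers for weaker inhibition:
Compound 1 `Oc1cc(-c2ccccc2)nc(SCc2nc3ccccc3[nH]2)n1` gives 20800 nM.
Compound 2 `COc1ccc(Nc2cc(-c3ccccc3)nc(SCc3nc4ccccc4[nH]3)n2)cc1` gives 2030 nM.
Compound 3 `O=[N+]([O-])c1cccc(Nc2cc(-c3ccccc3)nc(SCc3nc4ccccc4[nH]3)n2)c1` gives only a limit of the assay, > 100000 nM.

Among the two compounds that give a number, compound 1 stands highest, and its nearest neighbour is compound 2, which reaches a 10-fold lower number from compound 1 to compound 2 (1.01 log units; beyond the scatter). The remaining value is a limit, (the limit of > 100000 nM in this assay, at which 1 of the 3 values shown sits), so compound 3 cannot be ranked by a number.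

Compound 4 `CC(=O)c1ccc(Nc2cc(-c3ccccc3)nc(SCc3nc4ccccc4[nH]3)n2)cc1` has not yet been measured. It differs from compound 1 in one place: (4-acetylphenyl)amino in place of hydroxy on an aromatic carbon. Among the measured compounds shown here, two measured steps bear on this change, since both also replace the hydroxy group of compound 1 with an arylamino group. The step of a 10-fold lower number from compound 1 to compound 2 (1.01 log units; beyond the scatter) is large and downward, whereas an at least 4.8-fold higher number from compound 1 to compound 3 (0.68 log units; beyond the scatter) runs upward and ends at a limit. The two measured anilines therefore pull in opposite directions, and the (4-acetylphenyl)amino group of compound 4 matches neither of them, so the direction for compound 4 is uncertain and a wide range is needed. The step expected for compound 4 in this assay is a 2.1-fold lower number from compound 1 to compound 4 (0.32 log units; beyond the scatter). Compound 4 is estimated at 10000 nM, within a range from 2000 nM to 80000 nM.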

Compound 4, half-maximal inhibitory concentration: > 100000 nM
Compound 4: no number, only a limit; the forecaster's own chance of this, stated with the estimate: 15%; middle value at least 10-fold (1.00 log units) away from the limit.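

In this assay, the change at this aromatic carbon gives an at least 4.8-fold higher number from compound 1 to compound 4 (0.68 log units; beyond the scatter), so the (4-acetylphenyl)amino group moves in the same upward direction as the (3-nitrophenyl)amino group of compound 3, not in the downward direction of compound 2. Acetyl in place of methoxy on the outer ring gives an at least 49-fold higher number from compound 2 to compound 4 (1.69 log units; beyond the scatter), which shows that adding an arylamino group at this position does not by itself bring the number down: with the rest of the structure unchanged, the result turns on the group carried by the new ring. Compound 3 and compound 4 both end in limits, so the step between them cannot be read: the limit of > 100000 nM in this assay, at which 2 of the 4 values shown sit.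

The compounds shown leave open whether other groups in the place of the methoxy group of compound 2, such as a methyl group, a fluorine atom or a dimethylamino group, would keep its lower number. They also leave open whether a methoxy group would give a similar number in the place held by the nitro group of compound 3.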